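The compounds below may be only part of what the source reports. "The series", "measured", "known", "first", "only" and "open" are said of these compounds alone.

In a functional assay on HCC827 cells (Homo sapiens) for inhibition, read by MTT assay, with a stated time of 48 h, tested at 10 uM (on this read-out higher numbers stand for more inhibition at the one concentration tested (going by the name of the read-out) and lower numbers for less inhibition), compound 2 `COc1cc(NC(=O)Nc2cc(Nc3ccc(C)c(F)c3)ncn2)cc(OC)c1` gives 72%, the higher of the two numbers recorded, while compound 1 `COc1cc(NC(=O)Nc2cc(Nc3ccc(F)c(Cl)c3)ncn2)cc(OC)c1` gives 53.1%. For the measured compounds named here, the only measured step, a number 18.9 percentage points higher from compound 1 to compound 2 (beyond the scatter), shows that exchanging the ring on that nitrogen can move the read-out beyond the scatter. Compound 3 `COc1cc(NC(=O)Nc2cc(Nc3cc(F)ccc3OC)ncn2)cc(OC)c1` makes another such exchange: 5-fluoro-2-methoxyphenyl in place of 3-fluoro-4-methylphenyl on a nitrogen on an aromatic ring. Going by the values given here, no measured step covers this particular change, so its direction cannot be read from the data; a shift of similar size either way is possible. Compound 3 is therefore expected to give about 55%, between 30% and 80%. This change is estimated to amount to a number 17 percentage points lower from compound 2 to compound 3 (beyond the scatter).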

Compound 3, a percentage reported as inhibition, at one concentration (the size of the read-out at that concentration, not a potency): 59%
For compound 3 the middle estimate is 4 percentage points below the measured one; the range from low to high includes it.
By their numbers in this assay, from the lowest: compounds 1 and 3 (each within the scatter of the next); then compound 2.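

In this assay, 5-fluoro-2-methoxyphenyl on this nitrogen gives a number 13 percentage points lower from compound 2 to compound 3 (beyond the scatter), so a second change of ring also moves the read-out beyond the scatter. Set against 3-chloro-4-fluorophenyl, the same ring gives a number 5.9 percentage points higher from compound 1 to compound 3 (within the scatter), so these two rings cannot be told apart here, and 3-fluoro-4-methylphenyl alone stands above both. Nothing available gives a cause for these differences. Still open, on these data alone, is what a ring carrying an amine or a carboxylic acid would give at this nitrogen, or a longer chain in place of the ring.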